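Pyridyl to cyclopropylphenyl on the amino-triazole carboxamide

The compounds below may be only part of what the source reports. "The series", "measured", "known", "first", "only" and "open" are said of these compounds alone.

Measured so far:
compound 1 `COc1cccc(NC(=O)c2nnn(CC3CCNCC3)c2N)c1` — > 250000 nM
compound 2 `COc1cccc(NC(=O)c2nnn(Cc3ccc(OC(F)(F)F)cc3)c2N)c1` — 12000 nM
compound 3 `COc1cccc(NC(=O)c2nnn(Cc3ccncc3)c2N)c1` — < 12000 nM

In a physicochemical assay for solubility, read by nephelometry, at pH 7.4 (a lower number here means a less soluble compound, a higher number a more soluble compound), compound 1 reaches only a limit, > 250000 nM, so its true number is not known (the limit of > 250000 nM in this assay, at which 1 of the 3 values shown sits). In this assay compound 2 gives 12000 nM. Compound 3 also sits at a limit of this assay, < 12000 nM, and so stands at the low end of everything shown (the limit of < 12000 nM in this assay, at which 1 of the 3 values shown sits). Within the data shown here, the one measured step bearing on it is an at least 20-fold lower number from compound 1 to compound 3 (1.31 log units; beyond the scatter). Compound 4 `COc1cccc(NC(=O)c2nnn(Cc3ccc(C4CC4)cc3)c2N)c1` differs from compound 3 as follows: 4-cyclopropylphenyl in place of pyridin-4-yl on a saturated chain carbon bound to an aromatic nitrogen. Since compound 3 is already at the limit, the step that the limit leaves unreadable from compound 3 to compound 4 is expected to stay at or below it, and compound 4 is estimated at 5000 nM, between 1000 nM and 12000 nM.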

Compound 4, solubility: 79000 nM
Compound 4: middle estimate off by 16-fold (1.20 log units), on the low side; measured number above the stated range.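

In this assay, 4-cyclopropylphenyl in place of pyridin-4-yl gives an at least 6.5-fold higher number from compound 3 to compound 4 (0.81 log units; beyond the scatter), and cyclopropyl in place of trifluoromethoxy on an aromatic carbon gives a 6.6-fold higher number from compound 2 to compound 4 (0.82 log units; beyond the scatter), so a carbon-only aromatic ring at this place need not read low, and the group it carries shifts the number. Against piperidin-4-yl, 4-cyclopropylphenyl still gives an at least 3.1-fold lower number from compound 1 to compound 4 (0.50 log units; beyond the scatter). The values of compound 1 and compound 3 are limits, so the steps from them give only a minimum size. Open, from the compounds shown here alone, is how a carboxylic acid or an amine in place of cyclopropyl would read, and whether a longer chain to the ring would move the number.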